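Buffer stability notes on the shared core, toward compound 4

The compounds below may be only part of what the source reports. "The series", "measured", "known", "first", "only" and "open" are said of these compounds alone.

Measured so far:
- compound 1 `O=C1C=CC(=O)N1c1cc(C(F)(F)F)cc(C(F)(F)F)c1`: < 0.017 h
- compound 2 `C=Cc1cc(C(F)(F)F)cc(C(F)(F)F)c1`: > 50 h
- compound 3 `N#Cc1cc(C(F)(F)F)cc(C(F)(F)F)c1`: > 50 h

In an ADME assay for pharmacokinetics, read by HPLC, in phosphate buffer, with a stated time of 72 h, at pH 7.4, tested at 250 uM (a lower number here means that the compound disappears faster, a higher number that the compound lasts longer), compound 1 reports only a limit, < 0.017 h; it is not a number. Compound 2 reports a limit as well, > 50 h. Compound 3 likewise reports a limit, > 50 h, so it stands at the ceiling of this assay, as the limit of > 50 h in this assay, at which 2 of the 3 values shown sit, records. The readable steps are an at least 2900-fold higher number from compound 1 to compound 2 (3.46 log units; beyond the scatter) and an at least 2900-fold higher number from compound 1 to compound 3 (3.46 log units; beyond the scatter); the step from compound 2 to compound 3 cannot be read between the two limits. Compound 4 `O=C(CBr)c1cc(C(F)(F)F)cc(C(F)(F)F)c1` carries (bromomethyl)carbonyl in place of cyano on an aromatic carbon. Among the measured compounds shown here, no measured step covers this change; the large steps concern only the five-membered ring against a small group. For compound 4 the expectation is an at least 5.0-fold lower number from compound 3 to compound 4 (0.69 log units; beyond the scatter), an estimated 10 h within 1 h to 50 h.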

Compound 4, half-life: < 0.017 h
Compound 4 ended at the assay's limit; the forecaster's own chance of this, stated with the estimate: 20%; middle value at least 580-fold (2.76 log units) from the limit.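

In this assay, (bromomethyl)carbonyl on this aromatic carbon gives an at least 2900-fold lower number from compound 3 to compound 4 (3.46 log units; beyond the scatter) and an at least 2900-fold lower number from compound 2 to compound 4 (3.46 log units; beyond the scatter), so a drop of this size is no longer confined to the five-membered ring of compound 1. Compound 4 reports a limit, not a number: the limit of < 0.017 h in this assay, at which 2 of the 4 values shown sit. The step between compound 1 and compound 4 cannot be read, so these two groups cannot be ordered. The compounds shown leave open whether the drop follows the bromine or the carbonyl. A plain acetyl group or a chloromethyl ketone on the same carbon would separate the two.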